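Shortening the amide chain: from compound 1 to compound 4

The compounds below may be only part of what the source reports. "The series", "measured", "known", "first", "only" and "open" are said of these compounds alone.

Measured compounds:
compound 1 `CCCCCCCCCCCCCCCCCC(=O)Nc1nnc(S[C@@H]2O[C@H](CO)[C@H](O)[C@H](O)[C@H]2O)s1`: "not active" (no number reported)
compound 2 `CCCCCCCC(=O)Nc1nnc(S[C@@H]2O[C@H](CO)[C@H](O)[C@H](O)[C@H]2O)s1`: 56000 nM
compound 3 `CCCCCCCC/C=C\CCCCCCCC(=O)Nc1nnc(S[C@@H]2O[C@H](CO)[C@H](O)[C@H](O)[C@H]2O)s1`: "not active" (no number reported)

In a functional assay on SK-OV-3 cells (Homo sapiens) for cytotoxicity, read by MTT assay, with a stated time of 24 h (on this read-out lower numbers stand for stronger inhibition and higher numbers for weaker inhibition), compound 1 gives "not active" (no number reported) and no number is reported for it. Compound 3 likewise gives "not active" (no number reported) in this assay, again without a number. Only compound 2, which carries the shortest amide chain of the three, gives a number in this assay, 56000 nM, and it is a weak one. Compound 1 therefore stands at the inactive end of what is seen here, with compound 3 beside it.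

Compound 4 `CCCCCC(=O)Nc1nnc(S[C@@H]2O[C@H](CO)[C@H](O)[C@H](O)[C@H]2O)s1` differs from compound 1 by hydrogen in place of dodecyl on a saturated chain carbon, five bonds along the chain from a carbonyl carbon. Among the measured compounds shown here, no measured step covers this change. Since compound 2, with the shortest amide chain of the three measured compounds, gives 56000 nM in this assay, compound 4 is expected to land near that weak level, with a fair chance that only an inactive result is reported. The estimate for compound 4 in this assay is 70000 nM, ranging from 25000 nM to 200000 nM.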

Compound 4, half-maximal inhibitory concentration: "not active" (no number reported)
Compound 4 has no reported number here, and the estimate cannot be compared.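

In this assay compound 1 and compound 4 both lack a number, so no step can be read between them. The compounds shown leave open how amide chain length relates to cytotoxicity. No evidence bears on this result.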